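Fluorine added beside a retained methylsulfonyl on the aryl ring

The source may report more compounds than this note shows. Statements on the series, on what has been measured and on what is new or still open speak of the compounds shown alone.

Compound 1 `CS(=O)(=O)c1cccc(-c2c[nH]c3c(=O)n(Cc4cc(F)ccc4C#N)c(N4CCC[C@@H](N)C4)nc23)c1` is the starting point of this account. In an ADME assay on microsomes from liver (Homo sapiens) for metabolic stability, read by LC-MS, tested at 1 mM (on this read-out lower numbers stand for a shorter-lived compound and higher numbers for a longer-lived compound), compound 1 gives only a limit of the assay, > 3.33 h. Compound 2 `N#Cc1ccc(F)cc1Cn1c(N2CCC[C@@H](N)C2)nc2c(-c3ccc(S(N)(=O)=O)cc3)c[nH]c2c1=O` likewise gives only a limit of the assay in this assay, > 3.33 h. Compound 3 `CC(C)S(=O)(=O)c1ccc(-c2c[nH]c3c(=O)n(Cc4cc(F)ccc4C#N)c(N4CCC[C@@H](N)C4)nc23)cc1` gives a measured number in this assay, 0.722 h. The step of an at least 4.6-fold lower number from compound 1 to compound 3 (0.66 log units; beyond the scatter) and the step of an at least 4.6-fold lower number from compound 2 to compound 3 (0.66 log units; beyond the scatter) are both clear, while the step that the two limits leave unreadable from compound 1 to compound 2 cannot be sized because of the limit of > 3.33 h in this assay, at which 2 of the 3 values shown sit. On these data alone, compound 1 thus stands among the longer-lived compounds here, though its exact standing is unknown.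

Compound 4 `CS(=O)(=O)c1ccc(-c2c[nH]c3c(=O)n(Cc4cc(F)ccc4C#N)c(N4CCC[C@@H](N)C4)nc23)cc1F` differs from compound 1 in one place: 3-fluoro-4-(methylsulfonyl)phenyl in place of 3-(methylsulfonyl)phenyl on an aromatic carbon. Among the compounds with values here, no measured step introduces a fluorine; the two readable steps both concern the sulfonyl group itself, which here is kept. Compound 4 is therefore expected to show a step of a number no higher from compound 1 to compound 4 (the limit leaves the size open) in this assay, no change beyond the scatter. The half-life of compound 4 in this assay is estimated at 3.3 h, within 1.4 h to 8 h, with a fair chance that only a limit is reported.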

Compound 4, half-life: > 3.33 h
Compound 4 was reported as a limit; the forecaster's own chance of this, stated with the estimate: 55%; middle value at least 1.0-fold (0.00 log units) from the limit.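

Compound 4 carries its methylsulfonyl on a 3-fluoro-4-(methylsulfonyl)phenyl group and, like compound 1, reaches only the limit of this assay, so this position accepts that group with no readable shortening of half-life. The short half-life of compound 3 now stands apart, with an at least 4.6-fold higher number from compound 3 to compound 4 (0.66 log units; beyond the scatter). The steps to compound 4 from compound 1 and from compound 2 cannot be read, and the fluorine's share in the result stays hidden because of the shared limit: the limit of > 3.33 h in this assay, at which 3 of the 4 values shown sit.

On these data alone, what a half-life beyond that limit would be for compound 1, compound 2 or compound 4 remains open. So does whether a chlorine in place of the fluorine, or an ethylsulfonyl in place of the methylsulfonyl, would hold the half-life of compound 4 or move it towards that of compound 3.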